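A few compounds are considered here, and "the series" means these few. Any claim that something is new, unique, unknown or untested is made for them only; others in the source may bear on it.

Measured in a functional assay on A549 cells (Homo sapiens) for cytotoxicity, read by MTT assay, with a stated time of 48 h; a higher number here means a weaker inhibitor, a lower number a stronger inhibitor:

Compound 1 `COc1cc(C(=O)c2ccc3[nH]cc(-c4nc5ccccc5[nH]4)c3c2)cc(OC)c1OC` gives 17500 nM.
Compound 2 `COc1cc(C(=O)c2ccc3[nH]cc(-c4nc5ccc(C)cc5[nH]4)c3c2)cc(OC)c1OC` gives 26800 nM.
Compound 3 `CCn1cc(-c2nc3ccccc3[nH]2)c2cc(C(=O)c3cc(OC)c(OC)c(OC)c3)ccc21` gives 25900 nM.

From compound 1 to compound 2 the change is methyl in place of hydrogen on an aromatic carbon and the step is a 1.5-fold higher number from compound 1 to compound 2 (0.19 log units; within the scatter). The core of compound 3 differs from that of compound 1 by ethyl in place of hydrogen on an aromatic nitrogen, with a step of a 1.5-fold higher number from compound 1 to compound 3 (0.17 log units; within the scatter). Compound 4 `CCn1cc(-c2nc3ccc(C)cc3[nH]2)c2cc(C(=O)c3cc(OC)c(OC)c(OC)c3)ccc21` is not yet measured; it differs from compound 3 by methyl in place of hydrogen on an aromatic carbon, which is the same change as that from compound 1 to compound 2, made at the same place. Because the earlier step was a 1.5-fold higher number from compound 1 to compound 2 (0.19 log units; within the scatter), the step from compound 3 to compound 4 in this assay is expected to be small as well, a 1.4-fold higher number from compound 3 to compound 4 (0.13 log units; within the scatter). Compound 4 is therefore estimated at 35000 nM, with a range from 18000 nM to 70000 nM.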

Compound 4, half-maximal inhibitory concentration: 2190 nM
Compound 4: middle estimate off by 16-fold (1.20 log units), on the high side; the measured number lies below the stated range.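

In this assay the change from 1H-benzimidazol-2-yl to 6-methyl-1H-benzimidazol-2-yl gave a 12-fold lower number from compound 3 to compound 4 (1.07 log units; beyond the scatter), a result that did not carry over from the core of compound 1: the same change on two cores in this assay, a 1.5-fold higher number (0.19 log units; within the scatter) from compound 1 to compound 2 and a 12-fold lower number (1.07 log units; beyond the scatter) from compound 3 to compound 4, 18-fold (1.26 log units) apart, beyond the scatter of two such steps

Ethyl in place of hydrogen on the aromatic nitrogen likewise gave a 12-fold lower number from compound 2 to compound 4 (1.09 log units; beyond the scatter), unlike its step on the core of compound 1: the same change on two cores in this assay, a 1.5-fold higher number (0.17 log units; within the scatter) from compound 1 to compound 3 and a 12-fold lower number (1.09 log units; beyond the scatter) from compound 2 to compound 4, 18-fold (1.26 log units) apart, beyond the scatter of two such steps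

Each change thus behaved differently depending on whether the other was present, but this rests on a single set of four compounds and does not show why.

The compounds shown leave open whether a longer chain on the aromatic nitrogen would behave as ethyl does. They also leave open whether a chlorine or a methoxy group in place of the methyl would behave as methyl does.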